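A few compounds are considered here, and "the series" means these few. Any claim that something is new, unique, unknown or untested is made for them only; others in the source may bear on it.

Measured so far in an ADME assay on CHO cells (Cricetulus griseus) for cytotoxicity, read by MTT assay; a higher number here means that more compound is tolerated, a lower number that less compound is tolerated:

compound 1 `Fc1ccc(Nc2cc3[nH]c(Nc4ccc(N5CCN(CC6CC6)CC5)cn4)nc3cn2)cc1F` gives 1200 nM
compound 2 `C[C@@H]1CN(c2ccc(Nc3nc4cnc(Nc5ccc(F)c(F)c5)cc4[nH]3)nc2)C[C@H](C)N1` gives 2700 nM

Going by the values given here, compound 2 holds the highest of the two numbers; the only measured step is a 2.3-fold higher number from compound 1 to compound 2 (0.35 log units; beyond the scatter), and it separates the two beyond the scatter.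

Compound 3 `Fc1ccc(Nc2cc3[nH]c(Nc4ccc(C5CCNCC5)cn4)nc3cn2)cc1F` is not yet measured. Its change from compound 2: piperidin-4-yl in place of 3,5-dimethylpiperazin-1-yl on an aromatic carbon. Among the compounds with values here, the one step that bears on this change is the one from compound 1 to compound 2, which exchanged two saturated rings at the same aromatic carbon and moved the number modestly. The present change again exchanges the saturated ring at that carbon, so a step of similar modest size is plausible, but the direction cannot be read from one pair; a return toward the number of compound 1 is as likely as a further rise. Compound 3 is therefore expected to give about 1800 nM in this assay, within 700 nM to 4500 nM. The expected step is a 1.5-fold lower number from compound 2 to compound 3 (0.18 log units; within the scatter), within the scatter.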

Compound 3, half-maximal cytotoxic concentration in the CHO assay: 50000 nM
The estimate for compound 3 lay 28-fold (1.44 log units) below the measured number, and the stated range ends below it.
By their numbers in the CHO assay, from the lowest: compound 1; then compound 2; then compound 3.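

In the CHO assay, compound 3 gives 50000 nM, so the saturated ring on this aromatic carbon matters far more than the modest step suggested, a 2.3-fold higher number from compound 1 to compound 2 (0.35 log units; beyond the scatter): piperidin-4-yl gives a 19-fold higher number from compound 2 to compound 3 (1.27 log units; beyond the scatter) and a 42-fold higher number from compound 1 to compound 3 (1.62 log units; beyond the scatter), so the two piperazin-1-yl groups lie much closer to each other than either lies to piperidin-4-yl. Going by these compounds alone, in a physicochemical assay for solubility, read by HPLC, using the shake flask method, in phosphate buffer, measured as kinetic solubility, with a stated time of 20 h, at pH 6.5 (on this read-out lower numbers stand for lower solubility and higher numbers for higher solubility), the same exchange gives a 1.1-fold higher number from compound 2 to compound 3 (0.04 log units; within the scatter), with compound 2 at 175000 nM and compound 3 at 190000 nM, so the large step in tolerated compound comes with no step in solubility beyond the scatter. No measurement at hand gives a cause for the large step.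

Open, on these data alone, is whether the step follows the ring with one hetero atom or the attachment of the ring through carbon, which an unsubstituted piperazin-1-yl or a piperidin-1-yl group would help to separate. Also open, as far as these compounds go, is whether an alkyl group on the piperidine nitrogen, such as 1-methylpiperidin-4-yl or 1-(cyclopropylmethyl)piperidin-4-yl, keeps the number of compound 3.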